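The source may report more compounds than this note shows. Statements on the series, on what has been measured and on what is new or still open speak of the compounds shown alone.

Measured so far in a functional assay on HEp-2 cells (Homo sapiens) for cytotoxicity, read by sulforhodamine B assay, with a stated time of 48 h; on this read-out higher numbers stand for weaker inhibition and lower numbers for stronger inhibition
- compound 1 `CC(=O)N1N=C(c2cccc3ccccc23)CC1c1cccc(Br)c1` gives 9880 nM
- compound 2 `O=CCN1N=C(c2ccc3ccccc3c2)CC1c1ccccc1` gives 8400 nM
- compound 3 `O=CCN1N=C(c2ccc3ccccc3c2)CC1c1cccc([N+](=O)[O-])c1` gives 3870 nM

Of these three, compound 3 has the lowest number, which means the strongest inhibition in this small set. Going to the still unmeasured compound 4 `O=CCN1N=C(c2ccc3ccccc3c2)CC1c1ccccc1[N+](=O)[O-]` the structural change 2-nitrophenyl in place of 3-nitrophenyl on a saturated ring carbon puts 2-nitrophenyl in place of 3-nitrophenyl on a saturated ring carbon. Among the measured compounds shown here, only one measured step bears on this, namely a 2.2-fold lower number from compound 2 to compound 3 (0.34 log units; beyond the scatter) with nitro in place of hydrogen on an aromatic carbon. For the measured compounds named here, that step is modest, and no measured compound carries the nitro group in the new place, so the data give only a weak guide. Given the modest size of a 2.2-fold lower number from compound 2 to compound 3 (0.34 log units; beyond the scatter) as that guide, no step beyond the scatter is expected in this assay and the number may drift slightly upward. The expected change is a 1.2-fold higher number from compound 3 to compound 4 (0.07 log units; within the scatter) according to this estimate. Compound 4 is expected at 4500 nM with 2000 nM to 9500 nM as the estimated range.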

Compound 4, half-maximal inhibitory concentration: 3630 nM
Beside the measured number, compound 4's estimate is 1.2-fold (0.09 log units) above it; low and high end bracket the measured number.
By their numbers in this assay, from the lowest: compounds 4 and 3 (each within the scatter of the next); then compounds 2 and 1 (each within the scatter of the next).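

In this assay, moving the nitro group from its place in 3-nitrophenyl to its place in 2-nitrophenyl, on the same saturated ring carbon, gives a 1.1-fold lower number from compound 3 to compound 4 (0.03 log units; within the scatter), so these two placements cannot be told apart in this assay. Nitro in place of hydrogen on an aromatic carbon now lowers the number in both placements: the new case is a 2.3-fold lower number from compound 2 to compound 4 (0.36 log units; beyond the scatter), in the same direction as the earlier 2.2-fold lower number from compound 2 to compound 3 (0.34 log units; beyond the scatter), so among these three compounds the step is seen with either nitrophenyl group. No measurement at hand offers a reason for this result.

Going by these compounds, it remains open whether another group on that aromatic ring, such as an amine or a carboxylic acid, would lower the number as nitro does. On these data alone, it is equally open how a longer chain in place of the formylmethyl group would affect the number.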